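The source may hold more compounds than are shown below. What is called first, only, known or untested is meant among the compounds shown, and "the series" means these compounds.

Compound 1 `COc1ccc(SCc2ccc(C(=O)Nc3ccccc3N)cc2)cc1`: 80.1%
Compound 2 `Nc1ccccc1NC(=O)c1ccc(CSc2cccc(F)c2)cc1`: 83%
Compound 3 `Nc1ccccc1NC(=O)c1ccc(CSCCc2ccccc2)cc1`: 77.9%

These results come from a functional assay on SMMC-7721 cells (Homo sapiens) for inhibition, read by CCK-8 assay, with a stated time of 72 h, tested at 8 uM; a lower number here means less inhibition of growth, a higher number more inhibition of growth at the concentration tested. Here compound 3 gives 77.9%, which lies within the scatter of both other compounds. The next compound, compound 4 `Nc1ccccc1NC(=O)c1ccc(CSc2ccc(Cl)cc2)cc1`, has 4-chlorophenyl in place of phenethyl on a sulfur. Compound 1 and compound 2 also carry a substituted phenyl on that sulfur, so the closest evidence is a number 2.2 percentage points lower from compound 1 to compound 3 (within the scatter) and a number 5.1 percentage points lower from compound 2 to compound 3 (within the scatter). Both steps stay within the scatter, as does a number 2.9 percentage points higher from compound 1 to compound 2 (within the scatter). Going by the values given here, no chlorinated compound has been measured yet, so no step beyond the scatter is expected. The expected step is a number 3.1 percentage points higher from compound 3 to compound 4 (within the scatter). For compound 4 the estimate is 81%, with an expected range of 72% to 90%.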

Compound 4, percent growth inhibition at one concentration: 16.5%
Compound 4: middle estimate off by 64.5 percentage points, on the high side; measured number outside the range, below it.
By their numbers in this assay, from the lowest: compound 4; then compounds 3, 1 and 2 (each within the scatter of the next).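

In this assay, going by these compounds alone, the group on the sulfur proves far less forgiving than the earlier compounds suggested: chloro in place of methoxy on an aromatic carbon gives a number 63.6 percentage points lower from compound 1 to compound 4 (beyond the scatter). The 4-chlorophenyl group also gives a number 61.4 percentage points lower from compound 3 to compound 4 (beyond the scatter) and a number 66.5 percentage points lower from compound 2 to compound 4 (beyond the scatter), so carrying a substituted phenyl on that sulfur does not by itself keep the number high. Nothing available explains this drop. As far as these compounds go, whether it follows the chlorine itself or its place on the ring remains open. A 3-chlorophenyl or 4-bromophenyl group on the sulfur would help separate these two readings.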